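Swapping Methoxy for Methyl on a Shared Core

The source may hold more compounds than are shown below. What is called first, only, known or untested is meant among the compounds shown, and "the series" means these compounds.

Compound 1 `COc1cccc(-c2nc3cc(C)ccc3c(=O)[nH]2)c1` is the stronger of the two measured compounds in an assay on isolated protein for inhibition of DNA topoisomerase 1 (Homo sapiens), with a stated time of 30 min, tested at 20 uM; a lower number here means a weaker effect, a higher number a stronger effect of the compound at the concentration tested: here compound 1 gives 80%. Its companion, compound 2 `Cc1ccc2nc(-c3cccc(OC(F)(F)F)c3)[nH]c(=O)c2c1`, differs from compound 1 in more than one place, and in this assay compound 2 gives 0%, a gap beyond the usual scatter. Going by the values given here, no single-change step connects these two, so the values alone show that compound 1 stands highest of the pair.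

The next compound, compound 3 `Cc1cccc(-c2nc3cc(C)ccc3c(=O)[nH]2)c1`, is reached from compound 1 by one change: methyl in place of methoxy on an aromatic carbon. Among the compounds with values here, no measured pair shows what this particular change does, so any expectation rests only on compound 1 and on how far compound 2 falls from it. A moderate loss is expected, estimated as a number 25 percentage points lower from compound 1 to compound 3 (beyond the scatter), a decrease beyond the scatter. Compound 3 is therefore expected to give 55%, with a likely range from 20% to 85%.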

Compound 3, a percentage reported as inhibition, at one concentration (the size of the read-out at that concentration, not a potency): 56.3%
Estimate against measurement, compound 3: 1.3 percentage points below; the measured number falls inside the stated range.
By their numbers in this assay, from the lowest: compound 2; then compound 3; then compound 1.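

Methyl in place of methoxy on this aromatic carbon, meta to a large group, costs some effect in this assay: a number 23.7 percentage points lower from compound 1 to compound 3 (beyond the scatter). Going by these compounds alone, this is the first direct sign that the group at this place changes the read-out, yet the methoxy oxygen is not essential for activity, since compound 3 still gives 56.3%. Nothing available explains why the effect falls with this change.

From the compounds shown here alone, it remains open how an amine, a chlorine atom or a longer chain such as ethoxy would compare at this same place. Also open, going by these compounds, is whether the same swap would have a similar effect on another carbon of that ring.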